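The source may report more compounds than this note shows. Statements on the series, on what has been measured and on what is new or still open speak of the compounds shown alone.

Measured so far in a functional assay on the whole organism with Rattus norvegicus as the target, at a dose of 40 mg/kg by the intraperitoneal route; on this read-out higher numbers stand for more inhibition at the one dose given (going by the name of the read-out) and lower numbers for less inhibition:
compound 1 `CCCNc1c(C)nc2c(OCc3ccccc3)cccn12` gives 99%
compound 2 `Cc1nc2c(OCc3ccccc3)cccn2c1NCc1ccccc1` gives 48%

Compound 2 stands lowest of the two, with the step of a number 51 percentage points lower from compound 1 to compound 2 (beyond the scatter) setting it apart from compound 1 beyond the scatter. Compound 3 `Cc1nc2c(OCc3ccccc3)cccn2c1N(C)C` is the next step: dimethylamino in place of benzylamino on an aromatic carbon. Among the measured compounds shown here, the only measured step that bears on it is the one from compound 1 to compound 2, where the phenyl on the saturated chain carbon went with a large drop. Compound 3 gives up that phenyl, so a rise beyond the scatter is expected, though the loss of the hydrogen-bond donor is unread here. The step of a number 20 percentage points higher from compound 2 to compound 3 (beyond the scatter) is the estimate; compound 3 is expected at 68%, between 35% and 95%.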

Compound 3, a percentage reported as inhibition, in the whole organism at one dose (the size of the read-out at that dose, not a potency): 76%
For compound 3 the middle estimate is 8 percentage points below the measured one; the measured number falls inside the stated range.
By their numbers in this assay, from the lowest: compound 2; then compound 3; then compound 1.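

In this assay, dimethylamino on this aromatic carbon, with no hydrogen-bond donor, still gives strong inhibition at the one dose, and the step of a number 28 percentage points higher from compound 2 to compound 3 (beyond the scatter) places it clearly above benzylamino. The step of a number 23 percentage points lower from compound 1 to compound 3 (beyond the scatter) leaves it clearly below propylamino, so the three amino groups fall in the order benzylamino, dimethylamino, propylamino, and loss of the donor alone does not set the level. Nothing measured here accounts for this order.

Open, from the compounds shown here alone, is whether the lead of propylamino follows its chain or its nitrogen hydrogen. Methylamino and butylamino would help separate the two.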